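A Ketone in Place of an Amine on the Side Chain

This account rests on a few compounds, and the source may have more. Where it says the series, first, only, none or still open, it means among the compounds named here.

Three compounds share one core. Compound 1 `C=CCCn1c(=O)c2[nH]cnc2n(CCC)c1=O` gives 60 nM in an assay on Cerebral cortex for binding affinity to adenosine receptor A1 (Cavia porcellus), read by radioligand binding; a lower number here means a stronger inhibitor, a higher number a weaker inhibitor. Compound 2 `CCCn1c(=O)n(CCN(C)C)c(=O)c2[nH]cnc21` gives 4300 nM, and compound 3 `CCCn1c(=O)n(CCCN(C)C)c(=O)c2[nH]cnc21` gives 43200 nM, the highest number of the three. The steps of a 72-fold higher number from compound 1 to compound 2 (1.86 log units; beyond the scatter) and a 720-fold higher number from compound 1 to compound 3 (2.86 log units; beyond the scatter) are large, and a 10-fold higher number from compound 2 to compound 3 (1.00 log units; beyond the scatter) is modest.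

Compound 4 `CCCn1c(=O)n(CCC(C)=O)c(=O)c2[nH]cnc21` differs from compound 3 in one place: acetyl in place of (dimethylamino)methyl on a saturated chain carbon, two bonds along the chain from an aromatic nitrogen. The (dimethylamino)methyl group leaves and an acetyl group enters. Going by the values given here, no measured step tries this exchange, but the steps from compound 1 show how far the dimethylamino-bearing chains sit from the vinyl chain. A lower number is therefore expected for compound 4, estimated at 1500 nM (range 300 nM to 8000 nM), a step of a 29-fold lower number from compound 3 to compound 4 (1.46 log units; beyond the scatter).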

Compound 4, inhibition constant: 11200 nM
Estimate against measurement, compound 4: 7.5-fold (0.87 log units) below, and the stated range ends below it.
By their numbers in this assay, from the lowest: compound 1; then compound 2; then compound 4; then compound 3.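

In this assay the acetyl group gives a 3.9-fold lower number from compound 3 to compound 4 (0.59 log units; beyond the scatter) and so recovers only a small part of the ground lost by the amine chains. The same chain still shows a 2.6-fold higher number from compound 2 to compound 4 (0.42 log units; beyond the scatter) and a 190-fold higher number from compound 1 to compound 4 (2.27 log units; beyond the scatter) and so an amine-free chain at this place does not by itself return to the number of compound 1. Nothing available here gives a reason for these steps.

Going by these compounds, whether an alcohol, a carboxylic acid or a longer plain carbon chain at this place would come closer to compound 1 remains open.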